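Methoxy to hydroxy on the most active compound

The source may hold more compounds than are shown below. What is called first, only, known or untested is meant among the compounds shown, and "the series" means these compounds.

So far, three compounds that share one core have been tested in a functional assay on PC-3 cells (Homo sapiens) for cytotoxicity, read by sulforhodamine B assay, with a stated time of 48 h, tested at 100 nM; a lower number here means a stronger effect, a higher number a weaker effect of the compound at the concentration tested. Compound 1 `COc1cc(C)cc(-c2c(-c3ccnc(-c4ccc(C(C)=O)cc4)c3)cnn2CC#N)c1` gives 83%, and compound 2 `Cc1cc(O)cc(-c2nn(CC#N)cc2-c2ccnc(-c3ccc(Oc4ccccc4)cc3)c2)c1` gives 81%; these two values lie within the scatter of each other, so nothing separates them. Compound 3 `COc1cc(C)cc(-c2nn(CC#N)cc2-c2ccnc(-c3ccc(N(C)C)cc3)c2)c1` gives 14%, the lowest of the three and thus the strongest effect seen so far. Its gap to compound 2 is beyond the scatter, and its gap to compound 1 is slightly wider and also beyond the scatter.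

Compound 4 `Cc1cc(O)cc(-c2nn(CC#N)cc2-c2ccnc(-c3ccc(N(C)C)cc3)c2)c1` has not yet been measured. It differs from compound 3 in one place: hydrogen in place of methyl on an oxygen on an aromatic ring The methoxy becomes a hydroxy, so the 3-methoxy-5-methylphenyl group becomes 3-hydroxy-5-methylphenyl. Within the data shown here, no measured pair shows this change on its own, since compound 2 carries the hydroxy together with a phenoxy group and compound 1 carries the methoxy with an acetyl group, so the size of the step has to be guessed.

Because compound 3 gives 14% with the dimethylamino group in place, and compound 4 keeps that group, only a modest shift is expected for compound 4: a number 11 percentage points higher from compound 3 to compound 4 (beyond the scatter), if anything towards a weaker effect. Compound 4 is estimated at 25%, with a range from 8% to 60%.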

Compound 4, a percentage reported as activity, at one concentration (the size of the read-out at that concentration, not a potency): 94%
The estimate for compound 4 lay 69 percentage points below the measured number; the measured number lies above the stated range.
By their numbers in this assay, from the lowest: compound 3; then compounds 2 and 1 (each within the scatter of the next); then compound 4.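

In this assay, among these compounds, the step from methoxy to hydroxy can be read on its own for the first time, and a number 80 percentage points higher from compound 3 to compound 4 (beyond the scatter) shows that this small change, hydrogen in place of methyl on an oxygen on an aromatic ring, removes nearly all of the strong effect of compound 3. The dimethylamino group alone therefore does not carry that effect: with the hydroxy in place, the change to dimethylamino from phenoxy gives a number 13 percentage points higher from compound 2 to compound 4 (beyond the scatter), a modest step towards a weaker effect, so in this pair dimethylamino brings no gain over phenoxy. Nothing measured here accounts for the size of either step.

Among the compounds shown here, it remains open whether the same change from methoxy to hydroxy would matter as much with a phenoxy or acetyl group in place of dimethylamino, since only one such pair can be read. As far as these compounds go, it is also open whether a longer ether such as ethoxy, or an amine, on that oxygen-bearing carbon would keep the strong effect of compound 3 or lose it as the hydroxy does.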